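The compounds below may be only part of what the source reports. "The series", "measured", "known", "first", "only" and "open" are said of these compounds alone.

Measured in a functional assay on HL-60 cells (Homo sapiens) for antiproliferative activity, read by XTT assay, with a stated time of 72 h; a lower number here means a stronger inhibitor, a higher number a weaker inhibitor:
compound 1 `CNc1ncnc2c1c(-c1cc3ccccc3o1)cn2[C@@H]1O[C@H](CO)[C@@H](O)[C@H]1O`: 8950 nM
compound 2 `CN(C)c1ncnc2c1c(-c1ccoc1)cn2[C@@H]1O[C@H](CO)[C@@H](O)[C@H]1O`: 1160 nM

Compound 2 has the lower number of the two, and the gap to compound 1 lies beyond the scatter. These two compounds differ in more than one place, so the gap cannot be assigned to any single change.

The next compound is compound 3 `CN(C)c1ncnc2c1c(-c1cc3ccccc3o1)cn2[C@@H]1O[C@H](CO)[C@@H](O)[C@H]1O`, which has 1-benzofuran-2-yl in place of furan-3-yl on an aromatic carbon of compound 2: 1-benzofuran-2-yl in place of furan-3-yl on an aromatic carbon.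

Going by the values given here, no measured step isolates this change. Compound 1 carries the same 1-benzofuran-2-yl and gives 8950 nM, so a step beyond the scatter towards a higher number, a weaker inhibitor, is expected in this assay. The expected step is a 4.3-fold higher number from compound 2 to compound 3 (0.63 log units; beyond the scatter). The estimated value for compound 3 is 5000 nM, with an expected range of 1800 nM to 14000 nM.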

Compound 3, half-maximal inhibitory concentration: > 20000 nM
Compound 3 gave a limit, no number; the forecaster's own chance of this, stated with the estimate: 20%; middle value at least 4.0-fold (0.60 log units) away from the limit.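

In this assay, going by these compounds alone, 1-benzofuran-2-yl in place of furan-3-yl on this aromatic carbon gives an at least 17-fold higher number from compound 2 to compound 3 (1.23 log units; beyond the scatter), a large step and the first reading of this change on its own. With 1-benzofuran-2-yl held fixed, methyl in place of hydrogen on the nitrogen on the aromatic ring gives an at least 2.2-fold higher number from compound 1 to compound 3 (0.34 log units; beyond the scatter), so the group on that nitrogen also counts, by at least a modest step. Compound 3 gave a limit and not a number, so both steps are lower bounds: the limit of > 20000 nM in this assay, at which 1 of the 3 values shown sits.

The step from compound 2 to compound 3 changes the added six-membered ring and the point of attachment of the furan ring together, and the compounds shown do not separate the two. As far as these compounds go, a furan-2-yl group on the same core would tell them apart, and how a smaller group such as methyl behaves at this position stays open.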